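Working notes: trifluoromethyl removal from compound 2

The source may report more compounds than this note shows. Statements on the series, on what has been measured and on what is new or still open speak of the compounds shown alone.

Measured in a functional assay on the whole organism (blood) with Rattus norvegicus as the target; on this read-out lower numbers stand for an effect already at smaller amounts and higher numbers for an effect only at larger amounts of compound
compound 1 `CCOC(=O)C1(CCCc2ccc(Cl)cc2)CO1` gives 200 umol/kg
compound 2 `CCOC(=O)C1(CCCc2cccc(C(F)(F)F)c2)CO1` gives 170 umol/kg
compound 3 `O=C(O)C1(CCCc2cccc(C(F)(F)F)c2)CO1` gives 80 umol/kg

Compound 2 at 170 umol/kg lies at the upper end of these numbers, within the scatter of compound 1. Compound 4 (`CCOC(=O)C1(CCCc2ccccc2)CO1`) carries hydrogen in place of trifluoromethyl on an aromatic carbon. For the measured compounds named here, the only measured step, a 2.1-fold lower number from compound 2 to compound 3 (0.33 log units; beyond the scatter), is modest and falls elsewhere in the molecule, so it says little about this change. Going by the values given here, no measured step covers this aromatic carbon. In this assay no step beyond the scatter is therefore expected (estimated: a 1.3-fold higher number from compound 2 to compound 4 (0.11 log units; within the scatter)). Compound 4 is estimated at 220 umol/kg (expected range 100 umol/kg to 450 umol/kg).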

Compound 4, dose for half-maximal effect: 1170 umol/kg
The estimate for compound 4 lay 5.3-fold (0.73 log units) below the measured number; the measured number lies above the stated range.
By their numbers in this assay, from the lowest: compound 3; then compounds 2 and 1 (each within the scatter of the next); then compound 4.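

In this assay, this aromatic carbon proves sensitive to its substituent: hydrogen in place of trifluoromethyl gives a 6.9-fold higher number from compound 2 to compound 4 (0.84 log units; beyond the scatter), and hydrogen in place of chloro gives a 5.9-fold higher number from compound 1 to compound 4 (0.77 log units; beyond the scatter). Both steps run the same way, so among these three esters, compound 4, which carries hydrogen, stands apart from the two halogen-bearing compounds. No measured data on these compounds explain this difference.

Open, as far as these compounds go, is whether a methoxy group or a nitrile on the ring would match trifluoromethyl or chloro. Also open, from the compounds shown here alone, is whether the carboxylic acid form shows the same dependence on the ring substituent.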